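This account rests on a few compounds, and the source may have more. Where it says the series, first, only, none or still open, it means among the compounds named here.

Working notes on the xanthine riboside series.

Two compounds have numbers in an assay on CHO cells for displacement of a labelled ligand from adenosine receptor A3 (Rattus norvegicus); on this read-out higher numbers stand for weaker inhibition and lower numbers for stronger inhibition. Compound 1, `CCCn1c(=O)c2c(ncn2C2O[C@H](CO)[C@@H](O)[C@H]2O)n(CCC)c1=O`, with hydroxymethyl on the sugar and propyl chains on the core, gives in this assay 81200 nM. Compound 2, `CCCCn1c(=O)c2c(ncn2C2O[C@H](C(N)=O)[C@@H](O)[C@H]2O)n(CCCC)c1=O`, with carbamoyl on the sugar and butyl chains, gives in this assay 15300 nM, the lowest of the two numbers; compound 1 sits a good way above it, and the two structures differ in more than one place, so the gap cannot be tied to either change.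

Compound 3, `CCCCn1c(=O)c2c(ncn2C2O[C@H](OC(C)=O)[C@@H](O)[C@H]2O)n(CCCC)c1=O`, is the next member and has not been measured. It departs from compound 2 by one change: acetoxy in place of carbamoyl on a saturated ring carbon. Among the measured compounds shown here, no single-change pair shows what such a change does, so the step from compound 2 to compound 3 is read without precedent. The expectation is a step toward a weaker number, a 2.6-fold higher number from compound 2 to compound 3 (0.42 log units; beyond the scatter), modest and uncertain. Compound 3 is therefore estimated in this assay at 40000 nM, in a range from 12000 nM to 130000 nM.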

Compound 3, inhibition constant: 3230 nM
The estimate for compound 3 lay 12-fold (1.09 log units) above the measured number, outside the stated range (below it).
By their numbers in this assay, from the lowest: compound 3; then compound 2; then compound 1.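

Among the compounds shown here, compound 2 and compound 3 form the first single-change pair, and it gives the first reading at the saturated ring carbon next to the ring oxygen. In this assay, acetoxy in place of carbamoyl gives a 4.7-fold lower number from compound 2 to compound 3 (0.68 log units; beyond the scatter), so with butyl chains on the shared core, this position accepts the change with a gain in inhibition, and the 1 hydrogen-bond donor of carbamoyl is not required for the lower number. No evidence at hand accounts for this step.

One pair cannot show whether the lower number follows from losing the amide hydrogen or from something else in the acetoxy group. Also open, from the compounds shown here alone, are the outcomes for a carboxylic acid, a methyl ester or an N-methyl amide here, and the separate contribution of propyl against butyl chains.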